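Shifting a Trifluoromethyl Group Within a Shared Core

The source may report more compounds than this note shows. Statements on the series, on what has been measured and on what is new or still open speak of the compounds shown alone.

Of the compounds shown here, three have been measured in a functional assay on MCF7 cells (Homo sapiens) for inhibition, read by MTT assay, with a stated time of 72 h; a higher number here means a weaker inhibitor, a lower number a stronger inhibitor. Compound 1 `CN(C(=O)NC(=O)c1ccc(Cl)cc1Cl)c1nc(C(F)(F)F)c(C(=O)N/N=C/c2cccc(C(F)(F)F)c2)s1` gives 10.7 ug/mL, compound 2 `CN(C(=O)NC(=O)c1ccc(Cl)cc1Cl)c1nc(C(F)(F)F)c(C(=O)N/N=C/c2ccccc2C(F)(F)F)s1` gives 9.12 ug/mL, and compound 3 `CN(C(=O)NC(=O)c1ccccc1F)c1nc(C(F)(F)F)c(C(=O)N/N=C/c2ccccc2C(F)(F)F)s1` gives 12.2 ug/mL. The cores of compound 2 and compound 3 differ by 2-fluorophenyl in place of 2,4-dichlorophenyl on a carbonyl carbon, a change that gave a 1.3-fold higher number from compound 2 to compound 3 (0.13 log units; within the scatter). Compound 4 `CN(C(=O)NC(=O)c1ccccc1F)c1nc(C(F)(F)F)c(C(=O)N/N=C/c2cccc(C(F)(F)F)c2)s1` has not yet been measured; it differs from compound 3 by 3-(trifluoromethyl)phenyl in place of 2-(trifluoromethyl)phenyl on a carbon with a double bond to nitrogen. The same change, (3-(trifluoromethyl)phenyl in place of 2-(trifluoromethyl)phenyl on a carbon with a double bond to nitrogen), has been made once before in this series, where it gave a 1.2-fold higher number from compound 2 to compound 1 (0.07 log units; within the scatter). Resting on that single earlier step and on the value of compound 3, 12.2 ug/mL, the expected step is a 1.1-fold higher number from compound 3 to compound 4 (0.06 log units; within the scatter), a size still within the scatter. Compound 4 is therefore estimated at 14 ug/mL, with a likely span from 7 ug/mL to 28 ug/mL.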

Compound 4, half-maximal inhibitory concentration: 20.5 ug/mL
The estimate for compound 4 lay 1.5-fold (0.17 log units) below the measured number; measured number inside the range.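

Putting 3-(trifluoromethyl)phenyl in place of 2-(trifluoromethyl)phenyl on the second core gives a 1.7-fold higher number from compound 3 to compound 4 (0.23 log units; within the scatter) in this assay, and this agrees with the same change on the first core: the same change on two cores in this assay, a 1.2-fold higher number (0.07 log units; within the scatter) from compound 2 to compound 1 and a 1.7-fold higher number (0.23 log units; within the scatter) from compound 3 to compound 4, 1.4-fold (0.16 log units) apart, within the scatter of two such steps. The other change, 2-fluorophenyl in place of 2,4-dichlorophenyl, gives a 1.9-fold higher number from compound 1 to compound 4 (0.28 log units; within the scatter), which also agrees with its earlier step: the same change on two cores in this assay, a 1.3-fold higher number (0.13 log units; within the scatter) from compound 2 to compound 3 and a 1.9-fold higher number (0.28 log units; within the scatter) from compound 1 to compound 4, 1.4-fold (0.16 log units) apart, within the scatter of two such steps. Each change looks alike on the two cores it was read on, but every step lies within the scatter, so this does not show that either change has a real effect or that it would hold on a further core.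

On these data alone, it remains open whether a different group in place of the trifluoromethyl on the phenyl ring, such as a nitrile, an amine or a carboxylic acid, would give a step beyond the scatter. The same question stands for the other aryl ring, where only 2-fluorophenyl and 2,4-dichlorophenyl appear.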